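Stretching the tail from compound 2 to compound 3

The source may hold more compounds than are shown below. What is called first, only, known or untested is meant among the compounds shown, and "the series" means these compounds.

Compound 1 `O=C(NCc1ccc(F)cc1)c1nc(Br)c2cccnc2c1NCCCNc1c(C(=O)NCc2ccc(F)cc2)nc(Br)c2cccnc12` joins two copies of the shared core through a linker, and in a functional assay on MCF7 cells (Homo sapiens) for cytotoxicity, read by MTT assay, with a stated time of 72 h (a lower number here means a stronger inhibitor, a higher number a weaker inhibitor), compound 1 is recorded as "not determined" (no result reported). Compound 2 `CNCCCNc1c(C(=O)NCc2ccc(F)cc2)nc(Br)c2cccnc12` carries a single core. In this assay compound 2 gives > 10000 nM, which is a limit of the assay rather than a number. That is the limit of > 10000 nM in this assay, at which 1 of the 2 values shown sits. Compound 3 `NCCCCCCNc1c(C(=O)NCc2ccc(F)cc2)nc(Br)c2cccnc12` differs from compound 2 in one place: 3-aminopropyl in place of methylamino on a saturated chain carbon, three bonds along the chain from a nitrogen on an aromatic ring. Within the data shown here, no step between two measured compounds is available, so the change in this assay is expected to be none beyond the scatter. Compound 3 is expected to give 15000 nM, within a range from 5000 nM to 50000 nM. The step that the limit leaves unreadable from compound 2 to compound 3 is estimated to be small.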

Compound 3, half-maximal inhibitory concentration: 2000 nM
Compound 3: the middle estimate sits 7.5-fold (0.88 log units) above what was measured; the measured number lies below the stated range.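

In this assay, 3-aminopropyl in place of methylamino gives an at least 5.0-fold lower number from compound 2 to compound 3 (0.69 log units; beyond the scatter), so this position on the tail does affect the read-out, and compound 3 gives the first real number among the single-core compounds shown. The true size of the step stays unknown because compound 2 sits at a limit, not a number: the limit of > 10000 nM in this assay, at which 1 of the 3 values shown sits.

The change lengthens the chain and also replaces the methylamino end with an unsubstituted amine, and the compounds shown do not separate these two effects. A six-carbon chain ending in methylamino, or one ending in a carboxylic acid, would help tell them apart.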